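Chloro to Trifluoromethyl: Expecting Little Change in Growth Inhibition

The compounds below may be only part of what the source reports. "The series", "measured", "known", "first", "only" and "open" are said of these compounds alone.

Three compounds have been measured in a functional assay on WiDr cells (Homo sapiens) for inhibition, read by sulforhodamine B assay, with a stated time of 48 h; on this read-out higher numbers stand for weaker inhibition of growth and lower numbers for stronger inhibition of growth:

Compound 1, `COC(=O)[C@@]1(C)CCC=C2[C@@H]1CC[C@@H](C)[C@]2(C)Cc1c[nH]c2ccc(Cl)cc12`, gives 20000 nM.
Compound 2, `COC(=O)[C@@]1(C)CCC=C2[C@@H]1CC[C@@H](C)[C@]2(C)Cc1c[nH]c2ccc(C(F)(F)F)cc12`, gives 18000 nM.
Compound 3, `COC(=O)[C@@]1(C)CCC=C2[C@@H]1CC[C@@H](C)[C@]2(C)Cc1c(C)[nH]c2ccc(Cl)cc12`, gives 18000 nM.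

Compound 3 stands level with compound 2 at the digits shown, and these two together give the lowest numbers of the three; the gap to compound 1 is small, since the step of a 1.1-fold lower number from compound 1 to compound 3 (0.05 log units; within the scatter) lies within the scatter. Compound 4, `COC(=O)[C@@]1(C)CCC=C2[C@@H]1CC[C@@H](C)[C@]2(C)Cc1c(C)[nH]c2ccc(C(F)(F)F)cc12`, differs from compound 3 in one place: trifluoromethyl in place of chloro on an aromatic carbon.

For the measured compounds named here, one measured step bears directly on this change. The step of a 1.1-fold lower number from compound 1 to compound 2 (0.05 log units; within the scatter) is the same swap of chloro for trifluoromethyl, made on the core that lacks the methyl, and it stayed within the scatter. The added methyl itself, seen in the step of a 1.1-fold lower number from compound 1 to compound 3 (0.05 log units; within the scatter), also changed nothing beyond the scatter. With both earlier changes leaving the read-out flat, the expectation for the step of a 1.1-fold lower number from compound 3 to compound 4 (0.02 log units; within the scatter) is no change beyond the scatter in this assay. Compound 4 is therefore estimated at 17000 nM, with a likely range from 8000 nM to 36000 nM.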

Compound 4, concentration for 50% growth inhibition: 21000 nM
Compound 4: middle estimate off by 1.2-fold (0.09 log units), on the low side; the measured number falls inside the stated range.
By their numbers in this assay, from the lowest: compounds 2, 3, 1 and 4 (each within the scatter of the next).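

Compound 4 carries both changes at once, so the swap of chloro for trifluoromethyl can now be read on a second core. In this assay that swap gives a 1.2-fold higher number from compound 3 to compound 4 (0.07 log units; within the scatter), and it behaves alike with and without the added methyl: the same change on two cores in this assay, a 1.1-fold lower number (0.05 log units; within the scatter) from compound 1 to compound 2 and a 1.2-fold higher number (0.07 log units; within the scatter) from compound 3 to compound 4, 1.3-fold (0.11 log units) apart, within the scatter of two such steps The methyl on an aromatic carbon can also be read a second time, now with trifluoromethyl in place, as a 1.2-fold higher number from compound 2 to compound 4 (0.07 log units; within the scatter), and it too agrees with its earlier step: the same change on two cores in this assay, a 1.1-fold lower number (0.05 log units; within the scatter) from compound 1 to compound 3 and a 1.2-fold higher number (0.07 log units; within the scatter) from compound 2 to compound 4, 1.3-fold (0.11 log units) apart, within the scatter of two such steps In these four compounds, then, neither change goes beyond the scatter, whether made alone or together.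

Chloro and trifluoromethyl are the only two groups shown at this position, so an amine or a carboxylic acid on that same aromatic carbon remains an open case. As far as these compounds go, it also remains open whether any change to this core can move the read-out beyond the scatter.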